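A second aryl swap on the amide nitrogen

A few compounds are considered here, and "the series" means these few. Any claim that something is new, unique, unknown or untested is made for them only; others in the source may bear on it.

Compound 1 `Cc1cccc(NC(=O)COc2ccc(/C=C3\SC(=O)NC3=O)cc2)n1`: 10700 nM
Compound 2 `O=C(COc1ccc(/C=C2\SC(=O)NC2=O)cc1)Nc1ccc(Cl)cc1`: 7400 nM

Among the compounds with values here, in a functional assay on K562 cells (Homo sapiens) for inhibition (on this read-out lower numbers stand for stronger inhibition of growth and higher numbers for weaker inhibition of growth), compound 1 gives the highest of the two numbers, and compound 2 is nearest; the only measured step, a 1.4-fold lower number from compound 1 to compound 2 (0.16 log units; within the scatter), lies within the scatter. Compound 3 `Cc1cc(Br)ccc1NC(=O)COc1ccc(/C=C2\SC(=O)NC2=O)cc1` differs from compound 1 by 4-bromo-2-methylphenyl in place of 6-methylpyridin-2-yl on an amide-type nitrogen. That one measured step bears on it, since it too exchanged the 6-methylpyridin-2-yl on the amide-type nitrogen for a six-membered aromatic ring of carbon only and gave nothing beyond the scatter. A step of similar size, a 1.4-fold lower number from compound 1 to compound 3 (0.15 log units; within the scatter), is therefore expected. Compound 3 is estimated in this assay at 7500 nM, between 3000 nM and 20000 nM.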

Compound 3, concentration for 50% growth inhibition: 20700 nM
Compound 3: the middle estimate sits 2.8-fold (0.44 log units) below what was measured, outside the stated range (above it).
By their numbers in this assay, from the lowest: compounds 2, 1 and 3 (each within the scatter of the next, the first and the last beyond it).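

In this assay, the 4-bromo-2-methylphenyl group on the amide-type nitrogen stays within the scatter of the 6-methylpyridin-2-yl group (a 1.9-fold higher number from compound 1 to compound 3 (0.29 log units; within the scatter)) but not of the 4-chlorophenyl group (a 2.8-fold higher number from compound 2 to compound 3 (0.45 log units; beyond the scatter)). Two rings of carbon only therefore need not read alike at this position, and this is its first step beyond the scatter. No evidence explains this difference.

The compounds shown do not separate the bromine from the added methyl, since the two groups differ in both. On these data alone, how a carboxylic acid or an amine on this aryl ring would read also stays open.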